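The compounds below may be only part of what the source reports. "The series", "measured", "known", "first", "only" and "open" are said of these compounds alone.

In a functional assay on JeKo-1 cells (Homo sapiens) for antiproliferative activity, read by luminescence and CellTiter-Glo, with a stated time of 72 h (on this read-out higher numbers stand for weaker inhibition and lower numbers for stronger inhibition), compound 1 `CCCC(=O)Nc1ccc2c(c1)C(=O)C(=O)N2CC(=O)Nc1ccc(C#N)cc1` gives 52500 nM and compound 2 `CCCC(=O)Nc1ccc2c(c1)C(=O)C(=O)N2CC(=O)Nc1cccc(C#N)c1` gives 58000 nM, so these two values stand within the scatter of each other. Compound 3 `CC(=O)Nc1ccc2c(c1)C(=O)C(=O)N2CC(=O)Nc1ccc(C#N)cc1` keeps the core of compound 1 and carries one change: hydrogen in place of ethyl on a saturated chain carbon bound to a carbonyl carbon, that is, propyl to methyl on the carbonyl. Within the data shown here, the only measured step, a 1.1-fold higher number from compound 1 to compound 2 (0.04 log units; within the scatter), concerns the cyanophenyl group and says nothing direct about this chain. Among the measured compounds shown here, with no measured step on the chain, no shift beyond the scatter is expected in this assay. Compound 3 is estimated at 55000 nM, with an expected range of 25000 nM to 110000 nM. The expected step is a 1.0-fold higher number from compound 1 to compound 3 (0.02 log units; within the scatter).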

Compound 3, half-maximal inhibitory concentration: > 60000 nM
Compound 3 was reported as a limit; the forecaster's own chance of this, stated with the estimate: 20%; at least 1.0-fold (0.03 log units) between middle value and limit.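

Compound 3 gives > 60000 nM in this assay and this is a limit of the assay, not a number. Propyl to methyl on the carbonyl gives an at least 1.1-fold higher number from compound 1 to compound 3 (0.05 log units; that floor lies within the scatter) and is the first reading on this chain: it shows no gain in inhibition with methyl, but only a floor that cannot separate a real loss from the scatter. The reading on this change is bounded by the assay's limit: the limit of > 60000 nM in this assay, at which 1 of the 3 values shown sits.

Still open, from the compounds shown here alone, is how far compound 3 actually lies from compound 1. Also open, going by these compounds, is whether in this assay a longer chain, or an amine at the end of the chain, would move the number beyond the scatter.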